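Adding a chloro group to compound 3 in a glioblastoma cell assay

This account rests on a few compounds, and the source may have more. Where it says the series, first, only, none or still open, it means among the compounds named here.

Of the compounds shown here, three built on a shared core have been tested in a functional assay on U-87MG ATCC cells for antiproliferative activity against U-87 MG (Homo sapiens), read by MTT assay, with a stated time of 48 h; on this read-out higher numbers stand for weaker inhibition and lower numbers for stronger inhibition. Compound 1 `COc1ccc(-c2nc(SCC(=O)c3sc(-c4ccc(Cl)cc4)nc3C)[nH]c(=O)c2C#N)cc1OC` gives 38600 nM, compound 2 `Cc1nc(-c2ccc(Cl)cc2)sc1C(=O)CSc1nc(-c2ccccc2)c(C#N)c(=O)[nH]1` gives 27600 nM, and compound 3 `COc1cccc(-c2nc(SCC(=O)c3sc(-c4ccccc4)nc3C)[nH]c(=O)c2C#N)c1` gives 59700 nM, the highest of the three numbers, within the scatter of compound 1 but beyond it relative to compound 2. For the measured compounds named here, the only single-place step measured, a 1.4-fold lower number from compound 1 to compound 2 (0.15 log units; within the scatter), concerns a different part of the molecule and lies within the scatter. Compound 4 `COc1cccc(-c2nc(SCC(=O)c3sc(-c4ccc(Cl)cc4)nc3C)[nH]c(=O)c2C#N)c1` differs from compound 3 by chloro in place of hydrogen on an aromatic carbon. Going by the values given here, no measured step tests this change, so no shift beyond the scatter is expected. Compound 4 is therefore estimated at 40000 nM, within 15000 nM to 90000 nM, an expected step of a 1.5-fold lower number from compound 3 to compound 4 (0.17 log units; within the scatter).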

Compound 4, half-maximal inhibitory concentration: 41000 nM
Compound 4: the middle estimate sits 1.0-fold (0.01 log units) below what was measured; measured number inside the range.
By their numbers in this assay, from the lowest: compounds 2, 1, 4 and 3 (each within the scatter of the next, the first and the last beyond it).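

In this assay, chloro in place of hydrogen, para to a large group, gives a 1.5-fold lower number from compound 3 to compound 4 (0.16 log units; within the scatter). So phenyl to 4-chlorophenyl at this position leaves the number within the scatter. With the chloro present, the methoxy change also stays within the scatter in both listed steps: methoxy in place of hydrogen gives a 1.5-fold higher number from compound 2 to compound 4 (0.17 log units; within the scatter) and hydrogen in place of methoxy gives a 1.1-fold higher number from compound 1 to compound 4 (0.03 log units; within the scatter).

No further evidence bears on this result. As far as these compounds go, whether an amine, a carboxylic acid or a longer chain at this position would move the number beyond the scatter stays open.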